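Swapping methoxycarbonyl for ethoxycarbonyl in a cytotoxic series

This account rests on a few compounds, and the source may have more. Where it says the series, first, only, none or still open, it means among the compounds named here.

In a functional assay on A549 cells (Homo sapiens) for cytotoxicity, read by MTT assay, with a stated time of 72 h (a higher number here means a weaker inhibitor, a lower number a stronger inhibitor), compound 1 `COC(=O)c1sc2cc(OC)ccc2c1Nc1cc(OC)c(OC)c(OC)c1` gives 8.5 nM. Compound 2 `COC(=O)c1sc2cc(C)ccc2c1Nc1cc(OC)c(OC)c(OC)c1` gives 10.8 nM. These two values lie within the scatter of each other, so neither compound can be ranked over the other. Compound 3 `CCOC(=O)c1sc2cc(OC)ccc2c1Nc1cc(OC)c(OC)c(OC)c1` keeps the core of compound 1, but its methoxycarbonyl becomes ethoxycarbonyl: methyl in place of hydrogen on a saturated chain carbon bound to an oxygen next to a carbonyl group. In other words, methyl takes the place of hydrogen on a saturated chain carbon bound to an oxygen next to a carbonyl group. Going by the values given here, the only measured step, a 1.3-fold higher number from compound 1 to compound 2 (0.10 log units; within the scatter), is methyl in place of methoxy on an aromatic carbon, a different change in a different place. Among the compounds with values here, it bears only loosely on this question, and no measured compound varies the methoxycarbonyl. A change beyond the scatter is therefore not expected in this assay. The expected step is a 1.4-fold higher number from compound 1 to compound 3 (0.15 log units; within the scatter). The estimate for compound 3 is 12 nM, with an expected range from 4 nM to 35 nM.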

Compound 3, half-maximal inhibitory concentration: 8.9 nM
Compound 3: middle estimate off by 1.3-fold (0.13 log units), on the high side; the range from low to high includes it.
By their numbers in this assay, from the lowest: compounds 1, 3 and 2 (each within the scatter of the next).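

Going by these compounds alone, compound 3 gives the first reading on the ester group itself: in this assay, going from methoxycarbonyl to ethoxycarbonyl gives a 1.0-fold higher number from compound 1 to compound 3 (0.02 log units; within the scatter), so the two esters cannot be told apart. For this one pair, then, the position accepts an extra methyl at the end of the ester chain with no difference that this assay can resolve. No outside measurement bears on this result, so the data offer no explanation for it.

Going by these compounds, what happens with a longer chain such as a propyl ester, or when the ester gives way to a carboxylic acid or an amide, remains open. Within the data shown here, the swap is also seen only on the core of compound 1, so it is unknown whether the ethyl ester would read the same alongside the methyl group of compound 2.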